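The source may report more compounds than this note shows. Statements on the series, on what has been measured and on what is new or still open speak of the compounds shown alone.

Measured so far in a functional assay, with a stated time of 30 min, tested at 20 uM; a higher number here means more inhibition at the concentration tested (going by the name of the read-out), a lower number less inhibition:
- compound 1 `Oc1ccccc1-c1nnc(Nc2ncccn2)o1` gives 58.8%
- compound 2 `Clc1ccc(-c2nnc(Nc3ncccn3)o2)cc1` gives 46.2%

Compound 1 stands highest of the two numbers. The nearest is compound 2, whose inhibition is lower by a margin beyond the usual scatter of repeated measurements. Among the measured compounds shown here, the two compounds differ in more than one place, so no single step between them can be read off; their values show only that the hydroxy-bearing compound 1 lies above compound 2.

Compound 3 `O=[N+]([O-])c1ccccc1-c1nnc(Nc2ncccn2)o1` has not been measured. It differs from compound 1 in one place: nitro in place of hydroxy on an aromatic carbon. For the measured compounds named here, no measured pair covers a change of this kind, so the expectation rests on compound 1 alone. A modest fall in inhibition is expected in this assay, not a large one, with a fair chance that the step stays within the scatter. Compound 3 is estimated at 46%, with a range from 22% to 70%. The expected step is a number 12.8 percentage points lower from compound 1 to compound 3 (beyond the scatter).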

Compound 3, a percentage reported as inhibition, at one concentration (the size of the read-out at that concentration, not a potency): 51.8%
Beside the measured number, compound 3's estimate is 5.8 percentage points below it; measured number inside the range.
By their numbers in this assay, from the lowest: compounds 2, 3 and 1 (each within the scatter of the next, the first and the last beyond it).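

In this assay, nitro in place of hydroxy on an aromatic carbon, ortho to a large group, gives a number 7 percentage points lower from compound 1 to compound 3 (within the scatter), so this pair cannot be told apart at this position. Among the compounds shown here, the change swaps a group with 1 hydrogen-bond donor for one with 0 hydrogen-bond donors and adds heavy atoms, yet the read-out shows no step beyond the scatter, which the earlier compounds, differing in more than one place, could not show. No measurement at hand offers a reason for the size of this step.

On these data alone, whether an amine, a methoxy group or a carboxylic acid on the same carbon would also stay within the scatter of compound 1 remains open. Also open, as far as these compounds go, is whether a single pair like this one holds for other groups at this place on the ring.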